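Benzyl on the Amide Nitrogen: Expectation for Compound 4

This account rests on a few compounds, and the source may have more. Where it says the series, first, only, none or still open, it means among the compounds named here.

Compound 3 `COC(=O)/C=C/c1cccc(NC(=O)C2CCCCC2)c1` carries no substituent on its amide nitrogen. In an assay on isolated protein with Bile acid receptor (Homo sapiens) as the target (a lower number here means that less compound is needed, a higher number that more compound is needed for the effect), compound 3 reaches only a limit, > 1000 nM, so its position among the measured numbers is open, with the limit of > 1000 nM in this assay, at which 1 of the 3 values shown sits, marking where it sits. Compound 1 `COC(=O)/C=C/c1cccc(N(Cc2ccc(-c3ccc(F)c(F)c3)cc2)C(=O)C2CCCCC2)c1`, which carries a biaryl-substituted benzyl on that nitrogen, gives 72 nM in this assay, and compound 2 `COC(=O)/C=C/c1cccc(N(Cc2ccc(-c3cccc(Cl)c3)cc2)C(=O)C2CCCCC2)c1` gives 94 nM; the step of a 1.3-fold higher number from compound 1 to compound 2 (0.12 log units; within the scatter) shows that the two biaryl variants are not distinguished. Compound 4 `COC(=O)/C=C/c1cccc(N(Cc2ccccc2)C(=O)C2CCCCC2)c1` introduces (benzyl in place of hydrogen on an amide-type nitrogen), a plain benzyl without any further aryl. The only step measured so far concerns the distal ring, not the presence of the benzyl itself, so the gain from adding it is not directly shown; still, both benzyl-bearing compounds give numbers while compound 3 gives a limit. A step in the lower direction, beyond the scatter, is therefore expected, though smaller than what compounds 1 and 2 reach, giving an at least 2.5-fold lower number from compound 3 to compound 4 (0.39 log units; beyond the scatter) as the estimated step. Compound 4 is estimated at 400 nM, within 120 nM to 1500 nM.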

Compound 4, half-maximal effective concentration: > 1000 nM
Compound 4 ended at the assay's limit; the forecaster's own chance of this, stated with the estimate: 35%; middle value at least 2.5-fold (0.39 log units) away from the limit.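

In this assay, compound 3 and compound 4 both stand at a limit, so the step between them cannot be read, and the plain benzyl on the amide nitrogen is not shown to bring any readable gain: the limit of > 1000 nM in this assay, at which 2 of the 4 values shown sit.

The distal aryl group, by contrast, proves decisive: hydrogen in place of 3-chlorophenyl gives an at least 10-fold higher number from compound 2 to compound 4 (1.02 log units; beyond the scatter), and hydrogen in place of 3,4-difluorophenyl gives an at least 13-fold higher number from compound 1 to compound 4 (1.14 log units; beyond the scatter). Among these compounds, a number short of the limit appears only where the benzyl carries such an aryl group, as in compound 1 and compound 2.

From the compounds shown here alone, it remains open whether a non-aromatic group in that place, such as a cyclohexyl ring or a longer alkyl chain, would serve as well as an aryl group. Going by these compounds, it is also open whether a carboxylic acid in place of the methyl ester would keep the numbers of compound 1 and compound 2.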